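The source may report more compounds than this note shows. Statements on the series, on what has been measured and on what is new or still open speak of the compounds shown alone.

Measured compounds:
Compound 1 `CN1CCN(CC(=O)N2CCC3(N4CCCC4)CC(c4ccccc4)C2C(c2ccccc2)C3)CC1` gives 69100 nM in an ADME assay on L6 cells (Rattus norvegicus) for cytotoxicity; a lower number here means a stronger inhibitor, a higher number a weaker inhibitor.
Compound 2 `c1ccc(C2CC3(N4CCCCC4)CC(NCN4CCCC4)C2C(c2ccccc2)C3)cc1` gives 43000 nM in this assay.
Compound 3 `CCN1CCN(CCN2CCC3(N4CCCCC4)CC(c4ccccc4)C2C(c2ccccc2)C3)CC1` gives 67500 nM in this assay.

The three compounds share a core and differ in the groups hung from it. On the numbers shown, compound 2 stands at the smallest of the three values, yet its gaps to compound 3 and to compound 1 both lie within the usual scatter of this kind of measurement, so the three cannot be told apart on these data alone.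

The account now turns to compound 4 `c1ccc(C2CC3(N4CCCCC4)CC(NCCN4CCCC4)C2C(c2ccccc2)C3)cc1`, which has not yet been measured. Compound 4 differs from compound 2 in one place: (pyrrolidin-1-yl)methyl in place of pyrrolidin-1-yl on a saturated chain carbon bound to an amine nitrogen. The change adds a single chain carbon to a side group and leaves the count of donors and acceptors unchanged.

Within the data shown here, no pair of measured compounds differing in one place is available, so there is no measured step to lean on. With compound 2 giving 43000 nM and all three measured values sitting within the scatter of one another, no movement beyond the scatter is expected in this assay from such a small change. The step from compound 2 to compound 4 is therefore expected to be a 1.0-fold higher number from compound 2 to compound 4 (0.02 log units; within the scatter). Compound 4 is estimated to give 45000 nM, with a range from 20000 nM to 100000 nM.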

Compound 4, half-maximal inhibitory concentration: 27000 nM
For compound 4 the middle estimate is 1.7-fold (0.22 log units) above the measured one, and the stated range covers the measured number.
By their numbers in this assay, from the lowest: compounds 4, 2, 3 and 1 (each within the scatter of the next, the first and the last beyond it).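

Among these compounds, the step of a 1.6-fold lower number from compound 2 to compound 4 (0.20 log units; within the scatter) is the first one-place step available in this assay, and it falls on a saturated chain carbon bound to an amine nitrogen, where (pyrrolidin-1-yl)methyl gives way to 2-(pyrrolidin-1-yl)ethyl. It shows that, at this place and on these numbers, adding a single chain carbon to the side group gives no difference that can be told from the usual scatter of the measurement, so the two side groups cannot be separated here. No supporting measurement bears on this result.

What the compounds shown leave open is whether a longer chain, such as 3-(pyrrolidin-1-yl)propyl, would give a step beyond the scatter at this same place, or whether the chain length matters at all once the group grows further. From the compounds shown here alone, it is also open whether a different ring at the end of the chain, such as piperidin-1-yl or morpholin-4-yl in place of the pyrrolidin-1-yl ring, would give a step that can be read in this assay.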